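Urea series on a shared core: cytotoxicity notes

The compounds below may be only part of what the source reports. "The series", "measured", "known", "first", "only" and "open" are said of these compounds alone.

Measured so far in an ADME assay on BJ cells (Homo sapiens) for cytotoxicity, with a stated time of 72 h; a lower number here means that less compound is needed, a higher number that more compound is needed for the effect:
compound 1 `Cc1cc(NC(=O)Nc2ccccc2F)c2ccccc2n1`, reported only as a limit, > 25000 nM
compound 2 `Cc1cc(NC(=O)Nc2ccc(O)cc2)c2ccccc2n1`, reported only as a limit, > 25000 nM
compound 3 `Cc1cc(NC(=O)Nc2ccccc2N)c2ccccc2n1`, reported only as a limit, > 25000 nM

Compound 2 thus stands at the assay limit, with no number of its own, and the same holds for every value in the set (the limit of > 25000 nM in this assay, at which 3 of the 3 values shown sit). The steps that touch compound 2 are therefore unreadable: a step that the two limits leave unreadable from compound 1 to compound 2 and a step that the two limits leave unreadable from compound 2 to compound 3 give neither size nor direction, and a step that the two limits leave unreadable from compound 1 to compound 3 adds nothing further.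

Compound 4 `Cc1cc(NC(=O)Nc2ccc(C(F)(F)F)cc2)c2ccccc2n1` differs from compound 2 by trifluoromethyl in place of hydroxy on an aromatic carbon. Nothing measured here shows whether swapping substituents on that phenyl ring moves this read-out out of the limit region; every compound in the series sits at the limit (the limit of > 25000 nM in this assay, at which 3 of the 3 values shown sit). Accordingly a step of no readable size is expected, with the most likely outcome that compound 4 again returns only a limit in this assay.

Compound 4 is therefore estimated at 30000 nM, with a range of 12000 nM to 100000 nM. The implied step is estimated as a step that the limit leaves unreadable from compound 2 to compound 4, understood as no change beyond the scatter.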

Compound 4, half-maximal effective concentration: > 25000 nM
Compound 4 gave a limit, no number; the forecaster's own chance of this, stated with the estimate: 75%; the middle value is on the limit's open side.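

Compound 4 and compound 2 both return only a limit, so no step can be read between them, nor any other step in the series: the limit of > 25000 nM in this assay, at which 4 of the 4 values shown sit.

Still open, going by these compounds, is whether any change on the shared core would give a numerical value in this assay.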